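The compounds below may be only part of what the source reports. "The series", "measured", "known", "first", "only" and "open" are said of these compounds alone.

Measured compounds:
compound 1, `COc1cc(/C=N/Nc2nc(-c3ccccc3)cs2)c(Br)c(Br)c1OC`, with 33600 nM
compound 2, `COc1ccccc1-c1csc(N/N=C/c2cc(OC)c(OC)c(Br)c2Br)n1`, with > 100000 nM
compound 3, `COc1cc(/C=N/Nc2nc(-c3ccccc3)cs2)cc(Br)c1OC`, with 68300 nM

All three were tested in a functional assay on HepG2 cells (Homo sapiens) for inhibition, read by MTT assay, with a stated time of 48 h; on this read-out lower numbers stand for stronger inhibition and higher numbers for weaker inhibition. Compound 1 serves as the point of comparison. In this assay compound 1 gives 33600 nM. The value recorded for compound 2 is a limit of the assay, (the limit of > 100000 nM in this assay, at which 1 of the 3 values shown sits), and not a number. Going from compound 1 to compound 2 the change is methoxy in place of hydrogen on an aromatic carbon, and it gives an at least 2.9-fold higher number from compound 1 to compound 2 (0.47 log units; beyond the scatter). Going from compound 1 to compound 3 the change is hydrogen in place of bromo on an aromatic carbon, and in this assay it gives a 2.0-fold higher number from compound 1 to compound 3 (0.31 log units; beyond the scatter). Compound 3 therefore has the highest number of the two that were measured as numbers.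

Compound 4, `COc1ccccc1-c1csc(N/N=C/c2cc(Br)c(OC)c(OC)c2)n1`, has not yet been measured in this assay. It differs from compound 3 by methoxy in place of hydrogen on an aromatic carbon. For the measured compounds named here, this is the same kind of change as the one from compound 1 to compound 2, and the surroundings of the place are described in the same words in both cases. The two cores differ in the way given for compound 1 against compound 3, namely (hydrogen in place of bromo on an aromatic carbon).

On the basis of the earlier step, an at least 2.9-fold higher number from compound 1 to compound 2 (0.47 log units; beyond the scatter), a step of similar direction is expected here, starting from the higher number of compound 3. Compound 4 is therefore expected to give 200000 nM in this assay, with a range estimated from 80000 nM to 600000 nM. That expectation amounts to a step of a 2.9-fold higher number from compound 3 to compound 4 (0.47 log units; beyond the scatter), and it is expected that the assay may again report only a limit.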

Compound 4, half-maximal inhibitory concentration: 82100 nM
For compound 4 the middle estimate is 2.4-fold (0.39 log units) above the measured one; the measured number falls inside the stated range.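

In this assay, phenyl to 2-methoxyphenyl on the core of compound 3 gives a 1.2-fold higher number from compound 3 to compound 4 (0.08 log units; within the scatter), so on this core the change leaves the number within the scatter, and set beside the same change on the core of compound 1 the result reads: the same change on two cores in this assay, an at least 2.9-fold higher number (0.47 log units; beyond the scatter) from compound 1 to compound 2 and a 1.2-fold higher number (0.08 log units; within the scatter) from compound 3 to compound 4; the limit leaves it open whether they differ

The value of compound 2, > 100000 nM, is a limit of the assay and not a number.

The step of an at least 1.2-fold lower number from compound 2 to compound 4 (0.08 log units; that floor lies within the scatter) rests on that limit as well, so the steps that involve compound 2 cannot be read as sizes, and the account shows neither that the methoxy change carries over unchanged from one core to the other nor that it fails to, with the same holding for the loss of a bromo: the same change on two cores in this assay, a 2.0-fold higher number (0.31 log units; beyond the scatter) from compound 1 to compound 3 and an at least 1.2-fold lower number (0.08 log units; that floor lies within the scatter) from compound 2 to compound 4; the limit leaves it open whether they differ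

The compounds shown leave open what an amine, a hydroxyl or a carboxylic acid would do on the phenyl in place of the methoxy, and whether a longer chain such as ethoxy would behave as methoxy does. They also leave open whether chloro or fluoro in place of bromo would give a step like the one seen on the loss of bromo.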